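Swapping the Amide Heteroaryl on Two Related Cores

The source may report more compounds than this note shows. Statements on the series, on what has been measured and on what is new or still open speak of the compounds shown alone.

Compound 1 `COc1cc(N(C)C)c(NC(=O)c2ccncn2)cc1Nc1nccc(-c2cn(C)c3ccccc23)n1` and compound 2 `COc1cc(N(C)C)c(NC(=O)c2nccn2C)cc1Nc1nccc(-c2cn(C)c3ccccc23)n1` share one core and differ only in the group on the carbonyl carbon. In a functional assay on NCI-H1975 cells (Homo sapiens) for antiproliferative activity, read by MTT assay, with a stated time of 72 h (on this read-out higher numbers stand for weaker inhibition and lower numbers for stronger inhibition), compound 1 gives 1250 nM, and compound 2 gives 2880 nM. The change, (1-methyl-1H-imidazol-2-yl in place of pyrimidin-4-yl on a carbonyl carbon), brought a 2.3-fold higher number from compound 1 to compound 2 (0.36 log units; beyond the scatter).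

Compound 3 `COc1cc(N(C)CCN(C)C)c(NC(=O)c2ccncn2)cc1Nc1nc(-c2cn(C)c3ccccc23)c2cccnc2n1` rests on a different core; the difference between the two cores is not broken down here. In this assay compound 3 gives 1090 nM, a number within the scatter of compound 1 and beyond the scatter from compound 2.

Compound 4 `COc1cc(N(C)CCN(C)C)c(NC(=O)c2nccn2C)cc1Nc1nc(-c2cn(C)c3ccccc23)c2cccnc2n1` carries the same change as compound 2, now on the core of compound 3: 1-methyl-1H-imidazol-2-yl in place of pyrimidin-4-yl on a carbonyl carbon. The surroundings of the change read the same in both pairs, so this is the same change. Because the same change gave a 2.3-fold higher number from compound 1 to compound 2 (0.36 log units; beyond the scatter), compound 4 is expected to give 2500 nM. That expectation amounts to a 2.3-fold higher number from compound 3 to compound 4 (0.36 log units; beyond the scatter). Compound 4 is estimated to fall between 1200 nM and 5200 nM, with the width reflecting that the step has been seen only once.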

Compound 4, half-maximal inhibitory concentration: 4200 nM
Beside the measured number, compound 4's estimate is 1.7-fold (0.23 log units) below it, within the range that was stated.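

In this assay, placing 1-methyl-1H-imidazol-2-yl instead of pyrimidin-4-yl on the carbonyl carbon again gave a weaker result on the second core, with a 3.9-fold higher number from compound 3 to compound 4 (0.59 log units; beyond the scatter). The step therefore kept its direction on both cores, and its size did not differ beyond what repeated measurements would scatter: the same change on two cores in this assay, a 2.3-fold higher number (0.36 log units; beyond the scatter) from compound 1 to compound 2 and a 3.9-fold higher number (0.59 log units; beyond the scatter) from compound 3 to compound 4, 1.7-fold (0.22 log units) apart, within the scatter of two such steps. This supports carrying the change between these two cores in this assay, but two pairs do not show that it would hold on any further core, and they give no explanation for the loss of inhibition.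

The compounds shown leave open whether a phenyl or a pyridin-2-yl on the carbonyl carbon would rank with either of the two groups compared here. From the compounds shown here alone, it also remains open which of the differences between the two cores bears on the size of the step, and whether a morpholine in place of the dimethylamino-bearing chains would alter it.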